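Acetyl for Ethyl on the Imidazoline Ether Series

The source may hold more compounds than are shown below. What is called first, only, known or untested is meant among the compounds shown, and "the series" means these compounds.

Compound 1 `Cc1cccc(C)c1OC(C)C1=NCCN1` and compound 2 `CCc1ccccc1OC(C)C1=NCCN1` share a core and differ only at the aromatic ring. In an assay on CHO cells with Alpha-2C adrenergic receptor (Homo sapiens) as the target (on this read-out lower numbers stand for smaller maximal responses and higher numbers for larger maximal responses), compound 1 gives 0.82, and compound 2 gives 0.6, the lowest of the two numbers and beyond the scatter from compound 1. Compound 3 `CC(=O)c1ccccc1OC(C)C1=NCCN1` carries an acetyl where compound 2 carries an ethyl (acetyl in place of ethyl on an aromatic carbon). Within the data shown here, no measured pair shows this change, so compound 3 is expected to move little, a step of a number 0.050 lower from compound 2 to compound 3 (within the scatter) within or near the scatter. Compound 3 is therefore estimated at 0.55, within 0.35 to 0.8.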

Compound 3, intrinsic activity: the largest response reached, as a fraction of the reference agonist's: 0.65
Compound 3: middle estimate off by 0.10, on the low side; low and high end bracket the measured number.
By their numbers in this assay, from the lowest: compounds 2 and 3 (each within the scatter of the next); then compound 1.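

In this assay, acetyl in place of ethyl on this aromatic carbon gives a number 0.050 higher from compound 2 to compound 3 (within the scatter), the first one-place change read at this position. This position therefore takes acetyl, with its carbonyl and hydrogen-bond acceptor, without a shift beyond the scatter. Nothing at hand bears on why the two groups read alike. As far as these compounds go, what an amine, a carboxylic acid or a longer chain on this carbon would give in this assay remains open. So does whether this exchange would read the same with other groups on the ring.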